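This account rests on a few compounds, and the source may have more. Where it says the series, first, only, none or still open, it means among the compounds named here.

Three compounds built on one shared core were tested in a functional assay on DLD-1 cells (Homo sapiens) for inhibition, read by MTT assay, with a stated time of 72 h; a higher number here means a weaker inhibitor, a lower number a stronger inhibitor. Compound 1 `COc1cc(Oc2cccc(Nc3ccccc3)c2)cc(OC)c1CNCc1ccc(Cl)cc1` gives 3740 nM. Compound 2 `COc1cc(Oc2cccc(Nc3ccccc3)c2)cc(OC)c1CNCc1ccc(C)cc1` gives 6080 nM, and compound 3 `COc1cc(Oc2cccc(Nc3ccccc3)c2)cc(OC)c1CNCc1ccc(F)cc1` gives 2650 nM. The three differ only in one group on an aromatic carbon: the move a 1.6-fold higher number from compound 1 to compound 2 (0.21 log units; within the scatter) and the move a 1.4-fold lower number from compound 1 to compound 3 (0.15 log units; within the scatter) both stay within the scatter, while the move a 2.3-fold lower number from compound 2 to compound 3 (0.36 log units; beyond the scatter) is modest but beyond it. Compound 3 therefore holds the lowest of the three numbers, though its gap to compound 1 is within the scatter and only its gap to compound 2 lies beyond it.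

Compound 4 `COc1cc(Oc2cccc(Nc3ccccc3)c2)cc(OC)c1CCO` has not yet been measured in this assay. Its difference from compound 3 is hydroxymethyl in place of (4-fluorobenzyl)amino on a saturated chain carbon bound to an aromatic carbon. This change is of another kind than the three measured steps, which each exchanged one small group for another on an aromatic carbon and shifted the number by at most a modest amount. For the measured compounds named here, no measured step removes the whole (4-fluorobenzyl)amino group, so the measured steps give no direct guide to the size of this step; they show only that small exchanges moved the number little. The change takes away a large part of the molecule, and the number for compound 4 is expected to rise rather than fall, with wide uncertainty, the expected step being a 5.7-fold higher number from compound 3 to compound 4 (0.75 log units; beyond the scatter). Compound 4 is thus estimated at 15000 nM, within a range from 4000 nM to 60000 nM.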

Compound 4, half-maximal inhibitory concentration: 18100 nM
Compound 4: the middle estimate sits 1.2-fold (0.08 log units) below what was measured; the measured number falls inside the stated range.
By their numbers in this assay, from the lowest: compounds 3, 1 and 2 (each within the scatter of the next, the first and the last beyond it); then compound 4.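

The earlier compounds shown here only exchanged a small group on the outer aromatic ring, whereas this change removes the whole substituted benzylamino group from the saturated chain carbon, and in this assay the number rises at every comparison: a 6.8-fold higher number from compound 3 to compound 4 (0.83 log units; beyond the scatter) for the (4-fluorobenzyl)amino group, a 4.8-fold higher number from compound 1 to compound 4 (0.68 log units; beyond the scatter) for the (4-chlorobenzyl)amino group and a 3.0-fold higher number from compound 2 to compound 4 (0.47 log units; beyond the scatter) for the (4-methylbenzyl)amino group. All three steps lie beyond the scatter and none of the three compounds goes against this direction, so among these four compounds, those that carry a substituted benzylamino group give lower numbers than the one with hydroxymethyl in its place, while the loss still leaves a measurable number for compound 4. Nothing measured on these compounds explains why the number rises.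

The step removes a nitrogen and an aromatic ring together, so the compounds shown cannot separate what each contributes. A plain amine or a longer chain ending in an amine at this place, or a benzyl ether with oxygen in place of the nitrogen, would help to tell the two apart.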